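The source may hold more compounds than are shown below. What is called first, only, known or untested is meant among the compounds shown, and "the series" means these compounds.

Measured so far:
- compound 1, `Cc1nc2c(c(-c3cc(F)c4c(c3C)CCCO4)c1[C@H](OC(C)(C)C)C(=O)O)CN(CCCc1ccc(F)cc1)CC2`: > 40000 nM
- compound 2, `Cc1ccc(-c2c(C(OC(C)(C)C)C(=O)O)c(C)nc3ccccc23)cc1`: > 40000 nM

Both compounds were tested in an ADME assay on MT2 cells (Homo sapiens) for cytotoxicity, read by XTT assay, with a stated time of 4 days; on this read-out lower numbers stand for higher toxicity in this test and higher numbers for lower toxicity in this test. For compound 1 the value > 40000 nM is a limit of this assay, not a number; the compound showed no measurable toxicity up to the highest concentration tested. For compound 2 the value > 40000 nM is likewise a limit. So compound 1 stands where every value shown stands: the limit of > 40000 nM in this assay, at which 2 of the 2 values shown sit.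

The next compound, compound 3, `Cc1ccc(CCCN2CCc3nc(C)c([C@H](OC(C)(C)C)C(=O)O)c(-c4cc(F)c5c(c4C)CCCO5)c3C2)cc1`, is built from compound 1 by one change, (methyl in place of fluoro on an aromatic carbon). Within the data shown here, no step between two measured compounds of this kind is available here, so the expectation rests only on compound 1 and on the small size of the change. The expected step from compound 1 to compound 3 in this assay is a step that the limit leaves unreadable from compound 1 to compound 3, that is none beyond the usual scatter. Compound 3 is therefore estimated at 50000 nM, within a range from 20000 nM to 150000 nM, most likely again reported only as a limit.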

Compound 3, half-maximal cytotoxic concentration: > 40000 nM
Compound 3: a limit, no number; the forecaster's own chance of this, stated with the estimate: 85%; the middle value does not contradict the limit.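

Among these compounds, compound 1 and compound 3 both give a limit rather than a number, so no step between them can be read, because neither has a value that can be compared: the limit of > 40000 nM in this assay, at which 3 of the 3 values shown sit.

The compounds shown leave open whether 4-methylphenyl in place of 4-fluorophenyl alters toxicity in this assay at all, and at what concentration, if any, these compounds would harm the cells.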